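The source may hold more compounds than are shown below. What is called first, only, known or untested is meant among the compounds shown, and "the series" means these compounds.

Working notes on the urea series built on the shared core of compound 1 `NC(=O)N1CCN(C(=S)SCc2cn(Cc3ccc(F)cc3)nn2)CC1`. Among the measured compounds shown here, the three compounds measured so far differ only at the carbonyl carbon of the urea. In a functional assay on MGC-803 cells (Homo sapiens) for cytotoxicity, read by MTT assay, with a stated time of 72 h (on this read-out higher numbers stand for weaker inhibition and lower numbers for stronger inhibition), compound 1 gives 9330 nM. Compound 2 `CCNC(=O)N1CCN(C(=S)SCc2cn(Cc3ccc(F)cc3)nn2)CC1` gives 2170 nM in this assay, and compound 3 `CCN(C)C(=O)N1CCN(C(=S)SCc2cn(Cc3ccc(F)cc3)nn2)CC1` gives 1550 nM. Compound 3 thus has the lowest number of the three, though its step from compound 2 is a 1.4-fold lower number from compound 2 to compound 3 (0.15 log units; within the scatter), within the scatter, while the step from compound 1 is clear: a 6.0-fold lower number from compound 1 to compound 3 (0.78 log units; beyond the scatter). The other clear step is a 4.3-fold lower number from compound 1 to compound 2 (0.63 log units; beyond the scatter).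

Compound 4 `O=C(NC1CCCCC1)N1CCN(C(=S)SCc2cn(Cc3ccc(F)cc3)nn2)CC1` is not yet measured. The change from compound 3 is cyclohexylamino in place of ethyl(methyl)amino on a carbonyl carbon; cut one bond further out, it reads ethyl(methyl)carbamoyl to cyclohexylcarbamoyl. Compound 4 therefore carries one hydrogen-bond donor on the urea nitrogen, as compound 2 does, together with a six-membered ring of carbon. For the measured compounds named here, the steps that bear on it are a 4.3-fold lower number from compound 1 to compound 2 (0.63 log units; beyond the scatter), showing that alkyl on the urea nitrogen lowers the number clearly, and a 1.4-fold lower number from compound 2 to compound 3 (0.15 log units; within the scatter), showing that a further small alkyl adds nothing beyond the scatter. Going by the values given here, no measured step tells how a larger alkyl group behaves. Compound 4 is therefore expected to stay close to compound 3, with the step of a 1.2-fold lower number from compound 3 to compound 4 (0.08 log units; within the scatter) estimated to lie within the scatter. Compound 4 is estimated at 1300 nM in this assay, with a range from 450 nM to 3800 nM.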

Compound 4, half-maximal inhibitory concentration: > 128000 nM
Compound 4 gave a limit, no number; the forecaster's own chance of this, stated with the estimate: 2%; middle value at least 98-fold (1.99 log units) away from the limit.
By their numbers in this assay, from the lowest: compounds 3 and 2 (each within the scatter of the next); then compound 1. At a limit, above all of these: compound 4.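

Alkyl on the urea nitrogen does not lower the number whatever its kind: cyclohexylamino in place of ethyl(methyl)amino gives an at least 82-fold higher number from compound 3 to compound 4 (1.91 log units; beyond the scatter) in this assay and cyclohexyl in place of ethyl gives an at least 58-fold higher number from compound 2 to compound 4 (1.77 log units; beyond the scatter) on the same nitrogen. Compound 4 goes against the lowering seen from compound 1 to compound 2 and to compound 3, for cyclohexyl in place of hydrogen gives an at least 13-fold higher number from compound 1 to compound 4 (1.13 log units; beyond the scatter) in this series, so at this position the direction of the step depends on which alkyl group enters. These steps rest on a limit of the assay and not on a number, so their full size stays unknown: the limit of > 128000 nM in this assay, at which 1 of the 4 values shown sits.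

The compounds shown leave open where between ethyl and cyclohexyl the turn lies, which a propyl or butyl chain, a cyclopropyl or cyclopentyl ring, or a phenyl ring on the same nitrogen could place. They also leave open whether the ring itself or the remaining amide hydrogen goes with the loss, which an N-methyl-N-cyclohexyl urea or a piperidine amide on the carbonyl carbon would separate.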